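The source may report more compounds than this note shows. Statements on the series, on what has been measured and on what is new or still open speak of the compounds shown alone.

Measured in a toxicity assay on HUVEC cells (Homo sapiens) for inhibition; on this read-out higher numbers stand for weaker inhibition of growth and lower numbers for stronger inhibition of growth:
compound 1 `Cc1nc(-c2ccccc2F)c(C(=O)N2CCN(c3cc(Cl)cc(Cl)c3)CC2)o1`: 0.177 ug/mL
compound 2 `COc1cc(OC)cc(N2CCN(C(=O)c3oc(C)nc3-c3ccccc3F)CC2)c1`: 0.118 ug/mL
compound 3 `Cc1cc(C)cc(N2CCN(C(=O)c3oc(C)nc3-c3ccccc3)CC2)c1`: 0.356 ug/mL

Compound 3 stands within the scatter of compound 1 and beyond the scatter above compound 2. Compound 4 `Cc1nc(-c2ccccc2)c(C(=O)N2CCN(c3ccc(C)c(C)c3)CC2)o1` has 3,4-dimethylphenyl in place of 3,5-dimethylphenyl on an amine nitrogen in a ring. Within the data shown here, the one measured step at this place, a 1.5-fold lower number from compound 1 to compound 2 (0.18 log units; within the scatter), stayed within the scatter. Among the measured compounds shown here, no measured compound carries 3,4-dimethylphenyl, so the data suggest no direction, and no step beyond the scatter is expected in this assay. The estimated change is a 1.2-fold lower number from compound 3 to compound 4 (0.07 log units; within the scatter). For compound 4 the estimated value is 0.3 ug/mL, with an expected range from 0.13 ug/mL to 0.7 ug/mL.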

Compound 4, concentration for 50% growth inhibition: 3.52 ug/mL
Compound 4: middle estimate off by 12-fold (1.07 log units), on the low side, and the stated range ends below it.
By their numbers in this assay, from the lowest: compounds 2, 1 and 3 (each within the scatter of the next, the first and the last beyond it); then compound 4.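

In this assay, the change to 3,4-dimethylphenyl gave a 9.9-fold higher number from compound 3 to compound 4 (1.00 log units; beyond the scatter), although the leaving and entering groups hold the same atoms. At this place, the arrangement of two methyl groups alone moved the number beyond the scatter, which the earlier step, a 1.5-fold lower number from compound 1 to compound 2 (0.18 log units; within the scatter), had not shown. Nothing given here explains this shift.

Still open, on these data alone, is whether chlorine atoms or methoxy groups set out as in 3,4-dimethylphenyl would raise the number in the same way. As far as these compounds go, the place of a plain phenyl relative to compound 3 and compound 4 also remains open.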